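Notes on the sulfonyl substituent, compound 2 to compound 3

The source may hold more compounds than are shown below. What is called first, only, known or untested is meant among the compounds shown, and "the series" means these compounds.

Measured in a physicochemical assay for solubility, in phosphate buffer, with a stated time of 24 h, at pH 7.4, tested at 100 uM; a lower number here means a less soluble compound, a higher number a more soluble compound:
- compound 1 `O=C(NCc1ccc(S(=O)(=O)C2CCCOC2)cc1)N1Cc2ccncc2C1`: 208000 nM
- compound 2 `O=C(NCc1ccc(S(=O)(=O)C2CCN(C3COC3)CC2)cc1)N1Cc2ccncc2C1`: 121000 nM

On these two numbers, compound 2 stands within the scatter of compound 1, and the pair cannot be ranked. Next is compound 3 `O=C(NCc1ccc(S(=O)(=O)N2CCC[C@H](O)C2)cc1)N1Cc2ccncc2C1`, which carries 3-hydroxypiperidin-1-yl in place of 1-(oxetan-3-yl)piperidin-4-yl on a sulfonyl sulfur. For the measured compounds named here, the only measured step at this place is a 1.7-fold lower number from compound 1 to compound 2 (0.24 log units; within the scatter), with 1-(oxetan-3-yl)piperidin-4-yl in place of oxan-3-yl on a sulfonyl sulfur. That step does not involve the entering group, so it offers limited guidance. No step beyond the scatter is therefore expected in this assay, and no firm direction can be assigned. The estimated step is a 1.2-fold higher number from compound 2 to compound 3 (0.09 log units; within the scatter). For compound 3 the estimate is 150000 nM, with an expected range of 70000 nM to 260000 nM.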

Compound 3, solubility: 215000 nM
For compound 3 the middle estimate is 1.4-fold (0.16 log units) below the measured one, within the range that was stated.
By their numbers in this assay, from the lowest: compounds 2, 1 and 3 (each within the scatter of the next).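

In this assay, 3-hydroxypiperidin-1-yl on the sulfonyl sulfur gives a 1.8-fold higher number from compound 2 to compound 3 (0.25 log units; within the scatter), and against oxan-3-yl it gives a 1.0-fold higher number from compound 1 to compound 3 (0.01 log units; within the scatter), so all three compounds now lie within the scatter of one another. For the compounds shown here, the change from compound 2 to compound 3 swaps a group of 10 heavy atoms and 0 hydrogen-bond donors for one of 7 heavy atoms and 1 hydrogen-bond donor, and still no step at this position leaves the scatter. No accompanying measurement bears on why these numbers stay so close.

On these data alone, whether any group on the sulfonyl sulfur can move the number beyond the scatter remains open, for example a carboxylic acid or a primary amine carried on the piperidine ring. Also open, as far as these compounds go, is how the opposite stereocentre of 3-hydroxypiperidin-1-yl would compare with compound 3.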